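A few compounds are considered here, and "the series" means these few. Any claim that something is new, unique, unknown or untested is made for them only; others in the source may bear on it.

Working notes on the series in an assay on isolated protein for inhibition of Rap guanine nucleotide exchange factor 4 (Homo sapiens), read by fluorescence and cAMP accumulation; on this read-out lower numbers stand for stronger inhibition and higher numbers for weaker inhibition. Compound 1 `N#Cc1c(C2CCCCC2)nc(S)[nH]c1=O` carries a free sulfur on the shared core. For compound 1 this assay returns only a limit, > 300000 nM, the case recorded as the limit of > 300000 nM in this assay, at which 1 of the 2 values shown sits. Among the measured compounds shown here, compound 2 `Cc1ccc(CSc2nc(C3CCCCC3)c(C#N)c(=O)[nH]2)cc1`, with 4-methylbenzyl on that sulfur, gives 38700 nM in this assay and is the only compound with an actual number so far. For the measured compounds named here, the single measured step is an at least 7.7-fold lower number from compound 1 to compound 2 (0.88 log units; beyond the scatter), which concerns adding the whole benzyl group to the sulfur and says nothing about substitution within its ring. Compound 3 `Cc1cc(C)cc(CSc2nc(C3CCCCC3)c(C#N)c(=O)[nH]2)c1` differs from compound 2 by 3,5-dimethylphenyl in place of 4-methylphenyl on a saturated chain carbon bound to a sulfur. Going by the values given here, no measured step bears on such a change of methyl pattern, so the default expectation is a number close to compound 2, with no step beyond the scatter. Compound 3 is therefore estimated at 35000 nM, with a range of 12000 nM to 120000 nM. The expected step is a 1.1-fold lower number from compound 2 to compound 3 (0.04 log units; within the scatter).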

Compound 3, half-maximal inhibitory concentration: 7000 nM
For compound 3 the middle estimate is 5.0-fold (0.70 log units) above the measured one; measured number below the stated range.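

a 5.5-fold lower number from compound 2 to compound 3 (0.74 log units; beyond the scatter) in this assay shows that the number at this position depends on the methyl pattern on the ring, and not only on the presence of the whole benzyl group on the sulfur. The change both alters that pattern and adds one carbon, so these two compounds cannot separate the two differences. Nothing shown bears on the cause of this step.

Open, going by these compounds, is how this position responds to ring substituents other than methyl, such as chlorine, methoxy or a carboxylic acid, or to a longer chain in place of the saturated chain carbon bound to a sulfur. The cyclohexyl group and the nitrile are the same in all three compounds, so these compounds say nothing about their part in the numbers.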